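Urea series on MCF7 cells: ester to fluoride swap

This account rests on a few compounds, and the source may have more. Where it says the series, first, only, none or still open, it means among the compounds named here.

Values so far, all in a functional assay on MCF7 cells (Homo sapiens) for inhibition; on this read-out higher numbers stand for weaker inhibition and lower numbers for stronger inhibition:
compound 1 `CCOC(=O)c1ccc(NC(=O)N2CC2C#N)cc1` gives 3300 nM
compound 2 `N#CC1CN1C(=O)Nc1ccc(Cl)cc1Cl` gives 350 nM
compound 3 `N#CC1CN1C(=O)NC1CCCCC1` gives 9800 nM

Compound 1 stands second highest of the three numbers. Its nearest neighbour is compound 3, whose number is higher, beyond the scatter; the furthest is compound 2, whose number is lower, also beyond the scatter. Going by the values given here, no two of the measured compounds differ in one place only, so the three values fix an order but no single defined step.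

Compound 4 `N#CC1CN1C(=O)Nc1ccc(F)cc1` is not yet measured. Relative to compound 1 the change is: fluoro in place of ethoxycarbonyl on an aromatic carbon. Of the measured compounds, compound 2 carries halogens on the ring and shows the lowest number, while compound 1 with its ester and compound 3 without an aromatic ring sit higher. Compound 4 keeps the aromatic ring and takes on a halogen, so the number for compound 4 is expected to move downward from compound 1 by a 2.2-fold lower number from compound 1 to compound 4 (0.34 log units; beyond the scatter), beyond the scatter but short of compound 2. Compound 4 is estimated at 1500 nM, with a range from 500 nM to 4500 nM.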

Compound 4, half-maximal inhibitory concentration: 2700 nM
Beside the measured number, compound 4's estimate is 1.8-fold (0.26 log units) below it, and the stated range covers the measured number.
By their numbers in this assay, from the lowest: compound 2; then compounds 4 and 1 (each within the scatter of the next); then compound 3.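

Fluoro in place of ethoxycarbonyl on an aromatic carbon, para to a group of 8 heavy atoms, gives a 1.2-fold lower number from compound 1 to compound 4 (0.09 log units; within the scatter) in this assay, and this is the only comparison in the series so far that changes one place alone. At this position, then, an ethoxycarbonyl of 5 heavy atoms with 2 hydrogen-bond acceptors and a fluoro of 1 heavy atom with none cannot be told apart on this read-out, so neither the removal of the ester nor the arrival of the halogen registers as a change here. Nothing measured alongside these values bears on why the two compounds read alike.

The result covers only these two groups, so an amine, a carboxylic acid, a longer ester chain or plain hydrogen at this position could still separate from them in this assay. Going by these compounds alone, compound 2, at 350 nM, is joined by no single-place step to any other compound, which leaves open which feature of its ring goes with that value.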